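The compounds below may be only part of what the source reports. "The series", "measured", "known", "first", "only" and "open" are said of these compounds alone.

Measured compounds:
Compound 1 `Nc1cc(N)c2nc(-c3ccccc3)c(Sc3ccc(F)cc3)nc2c1` gives 61700 nM in a functional assay on U-251 cells (Homo sapiens) for inhibition, read by sulforhodamine B assay, with a stated time of 48 h; a lower number here means that less compound is tolerated, a higher number that more compound is tolerated.
Compound 2 `CCOC(=O)[C@H](CCC(=O)O)NC(=O)c1ccc(Oc2nc3cc(N)cc(N)c3nc2-c2ccccc2)cc1` gives in this assay only a limit, < 100000 nM.
Compound 3 `CCOC(=O)[C@H](CCC(=O)O)NC(=O)c1ccc(CNc2nc3cc(N)cc(N)c3nc2-c2ccccc2)cc1` gives in this assay only a limit, < 100000 nM.

Among the compounds with values here, compound 1 therefore stands alone as the one compound with a real number; the other two stop at the limit of < 100000 nM in this assay, at which 2 of the 3 values shown sit, so no step between measured compounds can be drawn from them, and no value can be called stronger or weaker than another.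

Compound 4 `Nc1cc(N)c2nc(-c3ccccc3)c(NCc3ccc(F)cc3)nc2c1` has not yet been measured. It differs from compound 1 in one place: (4-fluorobenzyl)amino in place of (4-fluorophenyl)sulfanyl on an aromatic carbon. Within the data shown here, none of the measured compounds shares this change, so nothing measured shows its direction in this assay. With no guide, the step from compound 1 to compound 4 is expected to stay within the usual scatter, in no particular direction. The expected step of a 1.0-fold lower number from compound 1 to compound 4 (0.01 log units; within the scatter) is accordingly small. Compound 4 is expected to give about 60000 nM, with a range from 20000 nM to 150000 nM.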

Compound 4, concentration lethal to 50% of the cells: 6310 nM
Beside the measured number, compound 4's estimate is 9.5-fold (0.98 log units) above it; the measured number lies below the stated range.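

In this assay, within the data shown here, placing (4-fluorobenzyl)amino instead of (4-fluorophenyl)sulfanyl on the aromatic carbon next to the ring nitrogen gives a 9.8-fold lower number from compound 1 to compound 4 (0.99 log units; beyond the scatter), the first readable step, and it shows that the group at this position can change the result beyond the scatter. The entering group differs from the leaving one in two ways at once: nitrogen replaces sulfur in the link, with a hydrogen-bond donor that the leaving group lacks, and an extra carbon separates that link from the fluorinated ring. Nothing shown explains why the number moves.

This single step cannot separate those two differences. A (4-fluorophenyl)amino group would test the nitrogen link without the extra carbon, while a longer chain between the nitrogen and the ring would show whether the trend continues.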